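The compounds below may be only part of what the source reports. "The series", "measured", "known", "first", "only" and "open" are said of these compounds alone.

Measured compounds:
Compound 1 `COc1cc(-c2nnc(SCc3ccccc3Cl)n2N2C(=O)c3ccccc3C2=O)cc(OC)c1OC`: in a functional assay on HepG2 cells (Homo sapiens) for cytotoxicity, read by MTT assay, with a stated time of 48 h (a higher number here means a weaker inhibitor, a lower number a stronger inhibitor), compound 1 gives > 200000 nM.
Compound 2 `COc1ccc(C(=O)CSc2nnc(-c3cc(OC)c(OC)c(OC)c3)n2N2C(=O)c3ccccc3C2=O)cc1`: in this assay compound 2 gives 28700 nM.

The value for compound 1 is a limit of the assay rather than a number (the limit of > 200000 nM in this assay, at which 1 of the 2 values shown sits). Among the compounds with values here, compound 2 therefore holds the only actual number among the two, and the step of an at least 6.9-fold lower number from compound 1 to compound 2 (0.84 log units; beyond the scatter) is the single measured step; it replaces a chlorophenyl directly on the chain with an aryl ketone, a change of a different kind from the one considered next.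

Compound 3 `COc1cc(-c2nnc(SCC(=O)c3ccc(F)c(F)c3)n2N2C(=O)c3ccccc3C2=O)cc(OC)c1OC` differs from compound 2 by 3,4-difluorophenyl in place of 4-methoxyphenyl on a carbonyl carbon. Within the data shown here, both compounds keep the ketone and the shared core, so the measured step from compound 1 to compound 2 does not bear on this exchange of one aryl group for another on the carbonyl carbon; no measured step does. With nothing to point in either direction, compound 3 is expected to stay within the scatter of compound 2, and the expected step of a 1.0-fold higher number from compound 2 to compound 3 (0.02 log units; within the scatter) is small. In this assay compound 3 is therefore estimated at 30000 nM, with a range from 9000 nM to 100000 nM.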

Compound 3, half-maximal inhibitory concentration: > 200000 nM
Compound 3: only a limit was reported; the forecaster's own chance of this, stated with the estimate: 12%; at least 6.6-fold (0.82 log units) between middle value and limit.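

In this assay, 3,4-difluorophenyl in place of 4-methoxyphenyl on a carbonyl carbon gives an at least 6.9-fold higher number from compound 2 to compound 3 (0.84 log units; beyond the scatter), so the aryl group on this carbonyl carbon matters, and the ketone and the shared core alone are not enough to give a measurable number. The result for compound 3 is a limit of the assay and not a number: the limit of > 200000 nM in this assay, at which 2 of the 3 values shown sit. Within the data shown here, compound 1 and compound 3 therefore both stand at a limit, the step between them cannot be read, and compound 2 remains the only one of the three with an actual number, which makes 4-methoxyphenyl the only aryl group on the carbonyl carbon seen to give one.

The exchange removes a methoxy group and brings in two fluorines at once, so the compounds shown leave open whether losing the one or gaining the other decides the step. Going by these compounds, how an unsubstituted phenyl, a 4-fluorophenyl, a 4-aminophenyl or a phenyl carrying a carboxylic acid on the same carbonyl carbon would read in this assay also stays open.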